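Exchanging the aryl group on the shared core

This account rests on a few compounds, and the source may have more. Where it says the series, first, only, none or still open, it means among the compounds named here.

In a functional assay on SW-620 cells (Homo sapiens) for cytotoxicity, read by sulforhodamine B assay, with a stated time of 48 h (on this read-out lower numbers stand for stronger inhibition and higher numbers for weaker inhibition), compound 1 `COc1ccc(C2=NO[C@]3(C2)C(=O)O[C@@H]2[C@H]3CC[C@H](C)[C@]3(O)C=CC(=O)[C@@]23C)cc1OC` gives 86000 nM and compound 2 `C[C@H]1CC[C@@H]2[C@@H](OC(=O)[C@]23CC(c2cccc([N+](=O)[O-])c2)=NO3)[C@]2(C)C(=O)C=C[C@@]12O` gives 49000 nM, so compound 2 stands within the scatter of compound 1. Compound 3 `C[C@H]1CC[C@@H]2[C@@H](OC(=O)[C@]23CC(c2ccccc2Cl)=NO3)[C@]2(C)C(=O)C=C[C@@]12O` carries 2-chlorophenyl in place of 3-nitrophenyl on a carbon with a double bond to nitrogen. Among the compounds with values here, one measured step bears on this place: a 1.8-fold lower number from compound 1 to compound 2 (0.24 log units; within the scatter), an exchange of one substituted phenyl for another that stays within the scatter. In this assay, no change beyond the scatter is therefore expected, and the estimated step is a 1.1-fold lower number from compound 2 to compound 3 (0.04 log units; within the scatter). Compound 3 is expected at 45000 nM, with an estimated range of 17000 nM to 100000 nM.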

Compound 3, half-maximal inhibitory concentration: 9000 nM
For compound 3 the middle estimate is 5.0-fold (0.70 log units) above the measured one; the whole stated range lies above it.
By their numbers in this assay, from the lowest: compound 3; then compounds 2 and 1 (each within the scatter of the next).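

The position on the carbon with a double bond to nitrogen had shown no change beyond the scatter, but in this assay 2-chlorophenyl in place of 3-nitrophenyl gives a 5.4-fold lower number from compound 2 to compound 3 (0.74 log units; beyond the scatter) and in place of 3,4-dimethoxyphenyl gives a 9.6-fold lower number from compound 1 to compound 3 (0.98 log units; beyond the scatter) on the shared core. Exchanging one substituted phenyl for another can therefore move the number beyond the scatter, though both steps are modest. Nothing available here explains this shift. Compound 3 is the only compound carrying chlorine, so the compounds shown do not separate the chlorine itself from its place on the phenyl ring. As far as these compounds go, how an amine, a carboxylic acid or a longer chain would behave on this carbon remains open.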